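The source may hold more compounds than are shown below. What is called first, only, known or untested is meant among the compounds shown, and "the series" means these compounds.

Measured so far in an ADME assay on THP-1 cells (Homo sapiens) for cytotoxicity; on this read-out higher numbers stand for weaker inhibition and lower numbers for stronger inhibition: compound 1 `COc1ccccc1-c1nnc(-c2ccc(C(=O)N/N=C/c3ccc(O)c(O)c3)cc2)o1` gives 100000 nM; compound 2 `COc1ccccc1-c1nnc(-c2ccc(C(=O)N/N=C/c3ccc(Cl)cc3Cl)cc2)o1` gives 78800 nM.

Compound 2 stands with compound 1 inside the usual scatter: the step of a 1.3-fold lower number from compound 1 to compound 2 (0.10 log units; within the scatter) is the only one in hand, and it is within the scatter. Compound 3 `COc1ccccc1-c1nnc(-c2ccc(C(=O)N/N=C/c3ccccn3)cc2)o1` differs from compound 2 by pyridin-2-yl in place of 2,4-dichlorophenyl on a carbon with a double bond to nitrogen. Going by the values given here, the one measured step that bears on this change is the aryl swap from compound 1 to compound 2, which moved nothing beyond the scatter, so for compound 3 no step beyond the scatter is expected in this assay, with a 1.0-fold higher number from compound 2 to compound 3 (0.01 log units; within the scatter) as the expected step. Compound 3 is estimated at 80000 nM, range 35000 nM to 180000 nM.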

Compound 3, half-maximal inhibitory concentration: 67000 nM
Compound 3: the middle estimate sits 1.2-fold (0.08 log units) above what was measured; low and high end bracket the measured number.
By their numbers in this assay, from the lowest: compounds 3, 2 and 1 (each within the scatter of the next).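

Pyridin-2-yl, the only ring at this place with a hetero atom, leaves this assay within the scatter of both other compounds (a 1.2-fold lower number from compound 2 to compound 3 (0.07 log units; within the scatter); a 1.5-fold lower number from compound 1 to compound 3 (0.17 log units; within the scatter)). Across the three aromatic rings shown on the carbon with a double bond to nitrogen, no step goes beyond the scatter, so this read-out does not separate them. Nothing at hand accounts for this flat result.

As far as these compounds go, whether a basic amine or a carboxylic acid at this place would give a step beyond the scatter remains open. Changes to the shared core also remain open.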